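The compounds below may be only part of what the source reports. "The series", "measured", "known", "first", "only" and "open" are said of these compounds alone.

Measured so far:
compound 1 `C#Cc1cccc(Nc2ncnc3cc(OC)c(OCCCCC(=O)Nc4ccc(S(N)(=O)=O)cc4)cc23)c1` gives 7720 nM in a functional assay on A549 cells (Homo sapiens) for antiproliferative activity, read by MTT assay, with a stated time of 72 h; on this read-out higher numbers stand for weaker inhibition and lower numbers for stronger inhibition
compound 2 `NS(=O)(=O)c1ccc(NC(=S)Nc2ccc3ncnc(Nc4cccc(C(F)(F)F)c4)c3c2)cc1` gives 10100 nM in this assay

Compound 2 carries the higher of the two numbers, but its gap to compound 1 lies within the scatter, so the two stand level in this assay. Compound 3 `CCc1ccc(Nc2ncnc3ccc(NC(=S)Nc4ccc(S(N)(=O)=O)cc4)cc23)cc1` has not been measured. It differs from compound 2 in one place: 4-ethylphenyl in place of 3-(trifluoromethyl)phenyl on a nitrogen on an aromatic ring. Within the data shown here, no measured step of this kind exists, so the expectation rests on compound 2 alone. The expected step is a 1.1-fold lower number from compound 2 to compound 3 (0.05 log units; within the scatter), not beyond the scatter in either direction. Compound 3 is estimated at 9000 nM, in a range from 3000 nM to 27000 nM.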

Compound 3, half-maximal inhibitory concentration: 24600 nM
Compound 3: middle estimate off by 2.7-fold (0.44 log units), on the low side; the range from low to high includes it.
By their numbers in this assay, from the lowest: compounds 1 and 2 (each within the scatter of the next); then compound 3.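

In this assay 4-ethylphenyl in place of 3-(trifluoromethyl)phenyl on the nitrogen gives a 2.4-fold higher number from compound 2 to compound 3 (0.39 log units; beyond the scatter) and so shows that the read-out responds to the group at this position. Both groups hold one six-membered aromatic ring of carbon only, so the step comes from a change in what that ring carries and where. No measurement shown accounts for the step.

On these data alone, whether the ethyl group, the loss of trifluoromethyl or the changed ring position drives the step stays open. So does the reading for a phenyl ring carrying an amine or a carboxylic acid.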